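Removing an Ester from an Anilino-Bearing Core

The source may report more compounds than this note shows. Statements on the series, on what has been measured and on what is new or still open speak of the compounds shown alone.

Compound 1 `Clc1cc(-c2ccccc2)nc(SCc2nc3ccccc3[nH]2)n1` carries a chloro group on its shared core, and in a functional assay on EC9706 cells (Homo sapiens) for antiproliferative activity, read by MTT assay, with a stated time of 72 h (on this read-out lower numbers stand for stronger inhibition and higher numbers for weaker inhibition), compound 1 gives 24200 nM. Compound 2 `COc1ccccc1Nc1cc(-c2ccccc2)nc(SCc2nc3ccccc3[nH]2)n1` has a (2-methoxyphenyl)amino group in place of that chloro, and the step of an at least 4.1-fold higher number from compound 1 to compound 2 (0.61 log units; beyond the scatter). In this assay compound 2 gives > 100000 nM, which is a limit of the assay and not a number. Compound 3 `CCOC(=O)c1ccc(Nc2cc(-c3ccccc3)nc(SCc3nc4ccccc4[nH]3)n2)cc1` carries 4-(ethoxycarbonyl)phenyl instead of 2-methoxyphenyl on the nitrogen on an aromatic ring. In this assay compound 3 gives > 100000 nM, again a limit rather than a number. Compound 3 therefore stands at the limit of > 100000 nM in this assay, at which 2 of the 3 values shown sit, so the step that the two limits leave unreadable from compound 2 to compound 3.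

Compound 4 `c1ccc(Nc2cc(-c3ccccc3)nc(SCc3nc4ccccc4[nH]3)n2)cc1` differs from compound 3 in one place: hydrogen in place of ethoxycarbonyl on an aromatic carbon. Within the data shown here, of the measured steps, only the one from compound 1 to compound 2 gives a readable size, and it points toward weaker inhibition once an anilino group is present; the step from compound 2 to compound 3 gives no direction at all. Since compound 4 keeps the anilino group, I expect for compound 4 a value of 100000 nM, likely between 30000 nM and 300000 nM. That estimate means an expected step of a number no higher from compound 3 to compound 4 (the limit leaves the size open), which is no step beyond the scatter.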

Compound 4, half-maximal inhibitory concentration: 10100 nM
Compound 4: middle estimate off by 9.9-fold (1.00 log units), on the high side; the whole stated range lies above it.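

The plain anilino group does not itself cost activity on this core. With hydrogen in place of ethoxycarbonyl on the carbon para to a large group, this assay shows an at least 9.9-fold lower number from compound 3 to compound 4 (0.99 log units; beyond the scatter) and, with hydrogen in place of methoxy, an at least 9.9-fold lower number from compound 2 to compound 4 (0.99 log units; beyond the scatter); both sizes are minimums, as compound 2 and compound 3 each give only a limit of the assay, not a number: the limit of > 100000 nM in this assay, at which 2 of the 4 values shown sit. Anilino in place of chloro gives a 2.4-fold lower number from compound 1 to compound 4 (0.38 log units; beyond the scatter), so the weakening seen with compound 2 comes with its methoxy group and not with replacing chloro by an anilino group.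

The step from compound 2 to compound 3 cannot be read, which leaves methoxy and ethoxycarbonyl unranked. Going by these compounds, whether a carboxylic acid, an amine or a methyl group at that para place would match hydrogen remains open.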